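From 2-bromophenyl to 3-bromo-4-fluorophenyl on a shared core

This account rests on a few compounds, and the source may have more. Where it says the series, first, only, none or still open, it means among the compounds named here.

Measured in a functional assay on Caco-2 cells (Homo sapiens) for inhibition, read by MTT assay, with a stated time of 48 h, tested at 10 uM; a higher number here means more inhibition of growth at the concentration tested, a lower number less inhibition of growth:
- compound 1 `Cc1oc2c([C@H]3CCN(C)C[C@H]3O)c(O)cc(O)c2c(=O)c1C(O)c1ccc([N+](=O)[O-])cc1`: 5%
- compound 2 `Cc1oc2c([C@H]3CCN(C)C[C@H]3O)c(O)cc(O)c2c(=O)c1C(O)c1ccccc1Br`: 7%

In this assay compound 2 gives 7%, level within the scatter with compound 1 at 5%. Compound 3 `Cc1oc2c([C@H]3CCN(C)C[C@H]3O)c(O)cc(O)c2c(=O)c1C(O)c1ccc(F)c(Br)c1` has 3-bromo-4-fluorophenyl in place of 2-bromophenyl on a saturated chain carbon bound to an aromatic carbon and an oxygen on a saturated carbon. Among the measured compounds shown here, one measured step bears on this change, a different swap at the same place: a number 2 percentage points higher from compound 1 to compound 2 (within the scatter). For the measured compounds named here, with only that step to go on, no change beyond the scatter is expected in this assay, and the estimated step is a number 1 percentage points higher from compound 2 to compound 3 (within the scatter). The expected value for compound 3 is 8%, with an estimated range of 1% to 20%.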

Compound 3, percent growth inhibition at one concentration: 6%
Compound 3: middle estimate off by 2 percentage points, on the high side, and the stated range covers the measured number.
By their numbers in this assay, from the lowest: compounds 1, 3 and 2 (each within the scatter of the next).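

In this assay, the swap to 3-bromo-4-fluorophenyl gives a number 1 percentage points lower from compound 2 to compound 3 (within the scatter), and measured against the 4-nitrophenyl group it gives a number 1 percentage points higher from compound 1 to compound 3 (within the scatter). All three substituted phenyl groups at this place therefore read level, so neither moving the bromine and adding a fluorine nor replacing the nitro group separates them in this assay. No evidence accounts for this level reading.

As far as these compounds go, whether a group of another kind at this place, such as an amine, a carboxylic acid or a longer chain, would move the number beyond the scatter remains open. The compounds shown also leave open whether any change elsewhere on the shared core would do so.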